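Fluoro for chloro on a shared core in the writhing test

The source may hold more compounds than are shown below. What is called first, only, known or untested is meant among the compounds shown, and "the series" means these compounds.

Measured so far:
compound 1, `COc1ccc(Cc2n[nH]c(=S)n2N)cc1`, 23.4%
compound 2, `COc1ccc(CCc2nnc3n2N=C(c2ccc(Cl)cc2)CS3)cc1`, 20.2%

Two compounds have numbers in a functional assay on the whole organism (strain BALB/c) with Mus musculus as the target, in the writhing test, with a stated time of 1 h, at a dose of 50 mg/kg by the oral route; on this read-out higher numbers stand for a stronger effect at the one dose given and lower numbers for a weaker effect. Compound 1 gives 23.4% and compound 2 gives 20.2%; the two numbers lie within the usual scatter of each other, so neither can be set above the other. For the measured compounds named here, no pair that differs in one place has been measured, so no step size is known from the data.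

Compound 3, `COc1ccc(CCc2nnc3n2N=C(c2ccc(F)cc2)CS3)cc1`, is not yet measured. It differs from compound 2 in one place: fluoro in place of chloro on an aromatic carbon. Going by the values given here, with no measured step to lean on, the change is expected to move the read-out in this assay by a number 0.2 percentage points lower from compound 2 to compound 3 (within the scatter), that is, by nothing beyond the scatter, in no firm direction. Compound 3 is therefore estimated to give 20% in this assay, with a range from 8% to 35%.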

Compound 3, a percentage reported as inhibition, in the whole organism at one dose (the size of the read-out at that dose, not a potency): 25%
The estimate for compound 3 lay 5 percentage points below the measured number; the range from low to high includes it.
By their numbers in this assay, from the lowest: compounds 2, 1 and 3 (each within the scatter of the next).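

For the compounds shown here, the step from chloro to fluoro is the first one-place comparison on this shared core in this assay: a number 4.8 percentage points higher from compound 2 to compound 3 (within the scatter). At this place, on an aromatic carbon para to a large group, 4-chlorophenyl and 4-fluorophenyl cannot be told apart by this read-out, so the exchange of these two groups shows no effect beyond the scatter. Nothing measured here bears on the reason for the size of this step.

On these data alone, whether a methoxy group, an amine or a carboxylic acid in place of the fluoro would stand apart from compound 2 and compound 3 in this assay remains open. The compounds shown also leave open how the read-out responds at this place to any group other than chloro and fluoro, and they give no measure of potency.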